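This account rests on a few compounds, and the source may have more. Where it says the series, first, only, none or still open, it means among the compounds named here.

Measured compounds:
compound 1 `CCOC(=O)CCC(=O)N1CCN(CCCOc2cc3c(Nc4ccc(F)c(Cl)c4)ncnc3cc2OC)CC1`, 77.6%; compound 2 `CCCOC(=O)CCC(=O)N1CCN(CCCOc2cc3c(Nc4ccc(F)c(Cl)c4)ncnc3cc2OC)CC1`, 95.1%; compound 3 `CCCCCCOC(=O)CCC(=O)N1CCN(CCCOc2cc3c(Nc4ccc(F)c(Cl)c4)ncnc3cc2OC)CC1`, 89.3%.

In a functional assay on A549 cells (Homo sapiens) for cytotoxicity, read by MTT assay, with a stated time of 24 h, tested at 10 uM (a higher number here means a weaker effect of the compound at the concentration tested, a lower number a stronger effect), compound 1 gives 77.6%. The change methyl in place of hydrogen on a saturated chain carbon, two bonds along the chain from an oxygen next to a carbonyl group produced the step of a number 17.5 percentage points higher from compound 1 to compound 2 (beyond the scatter). The longer extension butyl in place of hydrogen on a saturated chain carbon, two bonds along the chain from an oxygen next to a carbonyl group gave a number 11.7 percentage points higher from compound 1 to compound 3 (beyond the scatter), while a number 5.8 percentage points lower from compound 2 to compound 3 (within the scatter).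

Compound 4 `CCCCCCCOC(=O)CCC(=O)N1CCN(CCCOc2cc3c(Nc4ccc(F)c(Cl)c4)ncnc3cc2OC)CC1` is not yet measured. It differs from compound 3 by methyl in place of hydrogen on a saturated chain carbon, six bonds along the chain from an oxygen next to a carbonyl group. This is the same kind of change as from compound 1 to compound 2, but the place differs: there the methyl enters two bonds along the chain from an oxygen next to a carbonyl group, here six bonds along. The cores of compound 1 and compound 3 differ by butyl in place of hydrogen on a saturated chain carbon, two bonds along the chain from an oxygen next to a carbonyl group. Since the step from compound 2 to compound 3 was a number 5.8 percentage points lower from compound 2 to compound 3 (within the scatter), a small step of a number 1.7 percentage points higher from compound 3 to compound 4 (within the scatter) is expected. Compound 4 is estimated at 91%, between 78% and 100%.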

Compound 4, a percentage reported as activity, at one concentration (the size of the read-out at that concentration, not a potency): 89.1%
Compound 4: the middle estimate sits 1.9 percentage points above what was measured; the measured number falls inside the stated range.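

Extending the chain does not carry over as a fixed increment from one core to another in this assay, as the methyl change shows: the same change on two cores in this assay, a number 17.5 percentage points higher (beyond the scatter) from compound 1 to compound 2 and a number 0.2 percentage points lower (within the scatter) from compound 3 to compound 4, 17.7 percentage points apart, beyond the scatter of two such steps

The butyl change behaves the same way: the same change on two cores in this assay, a number 11.7 percentage points higher (beyond the scatter) from compound 1 to compound 3 and a number 6 percentage points lower (within the scatter) from compound 2 to compound 4, 17.7 percentage points apart, beyond the scatter of two such steps

Only a number 11.5 percentage points higher from compound 1 to compound 4 (beyond the scatter) lies beyond the scatter, while a number 0.2 percentage points lower from compound 3 to compound 4 (within the scatter) and a number 6 percentage points lower from compound 2 to compound 4 (within the scatter) do not separate these compounds; with a single pair of cores for each change, this shows dependence on the core in these pairs but gives neither a cause nor a general rule.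

The compounds shown leave open how a carboxylic acid in place of the ester, an amine at the chain end, or a longer chain than in compound 4 would read.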